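The source may report more compounds than this note shows. Statements on the series, on what has been measured and on what is new or still open speak of the compounds shown alone.

Measured so far in a physicochemical assay for solubility, using potentiometric titration; on this read-out higher numbers stand for higher solubility and lower numbers for lower solubility:
compound 1 `Fc1ccc(-c2nc(-c3ccc4nc[nH]c4c3)no2)cc1F`: 99000 nM
compound 2 `Cc1ccnc(-c2noc(-c3ccc(F)c(F)c3)n2)c1`: 220000 nM
compound 3 `Fc1ccc(-c2nc(-c3ccc(-c4ccccc4)cc3)no2)cc1F`: 16000 nM

Compound 3 stands lowest of these three, at 16000 nM. Both others lie beyond the scatter from it, with compound 1 the nearest at 99000 nM and compound 2 the furthest at 220000 nM.

The compound still awaiting measurement is compound 4 `Cc1ccc(-c2noc(-c3ccc(F)c(F)c3)n2)cc1`. It has methyl in place of phenyl on an aromatic carbon, para to a large group, and the count of that difference reads (methyl in place of phenyl on an aromatic carbon).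

For the measured compounds named here, no pair of measured compounds differs in one place only, so nothing here sizes this change directly, and any expectation is a loose one. It rests on the spread of the three values: compound 3 sits at the bottom with 16000 nM, and compound 2, which also carries a methyl, reads 220000 nM. A rise in this assay beyond the scatter therefore seems likely, though compound 4 is not expected to reach the top of that spread. The expected change is a 2.8-fold higher number from compound 3 to compound 4 (0.45 log units; beyond the scatter). For compound 4 the estimated value is 45000 nM, with an expected range from 20000 nM to 110000 nM.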

Compound 4, solubility: 35000 nM
Estimate against measurement, compound 4: 1.3-fold (0.11 log units) above; measured number inside the range.
By their numbers in this assay, from the lowest: compound 3; then compound 4; then compound 1; then compound 2.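

In this assay, putting methyl in place of phenyl on an aromatic carbon, para to a large group, gives a 2.2-fold higher number from compound 3 to compound 4 (0.34 log units; beyond the scatter), a modest step that nonetheless lies beyond the usual scatter. For the compounds shown here, this is the first pair to differ in one place only, so the earlier compounds could offer only a loose spread of values, whereas this position now has one directly measured change in this read-out. The step gives its size and direction but not its origin, and no supporting measurement bears on why the number moves.

The compounds shown leave open whether this position would respond in the same direction and to a similar extent with other groups, such as an amine, a carboxylic acid or a longer alkyl chain. Going by these compounds alone, they also leave open whether methyl in place of phenyl would give a step of similar size on a different core, since this single pair is the only reading of the change.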